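Chloro in Place of Methyl: an Expected Inhibition Value

A few compounds are considered here, and "the series" means these few. Any claim that something is new, unique, unknown or untested is made for them only; others in the source may bear on it.

Measured compounds and their inhibition values:
compound 1, `Cc1nc(-c2ccc(Cl)cc2)sc1C1SCC(=O)N1c1ccc(F)c(Cl)c1`: 53.4%
compound 2, `Cc1ccc(N2C(=O)CSC2c2sc(Cc3ccc(Cl)cc3)nc2C)cc1`: 59.9%
compound 3, `Cc1nc(-c2ccccc2)sc1C1SCC(=O)N1c1ccc(F)c(Cl)c1`: 55.9%

In a functional assay on the whole organism (strain Wistar albino) for inhibition, with Rattus norvegicus as the target, read by paw edema, with a stated time of 1 h, at a dose of 40 mg/kg by the oral route (on this read-out higher numbers stand for more inhibition at the one dose given (going by the name of the read-out) and lower numbers for less inhibition), compound 2 gives 59.9%. Compound 1 gives 53.4% and compound 3 gives 55.9%, so all three numbers lie within the usual scatter of one another and compound 2 is not set apart from its neighbours. The unmeasured compound 4, `Cc1nc(Cc2ccc(Cl)cc2)sc1C1SCC(=O)N1c1ccc(Cl)cc1`, differs from compound 2 in one place: chloro in place of methyl on an aromatic carbon. Going by the values given here, no measured pair shows this exchange. Among the compounds with values here, the only measured step, a number 2.5 percentage points higher from compound 1 to compound 3 (within the scatter), concerns another exchange, hydrogen in place of chloro on an aromatic carbon, and stayed within the scatter. Compounds 1 and 3 already carry chloro on an aromatic carbon and give numbers close to compound 2 with its methyl, which gives no ground to expect a shift beyond the scatter. Compound 4 is therefore expected to give about 57% in this assay, within 45% to 68%, an estimated step of a number 2.9 percentage points lower from compound 2 to compound 4 (within the scatter).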

Compound 4, a percentage reported as inhibition, in the whole organism at one dose (the size of the read-out at that dose, not a potency): 48.9%
For compound 4 the middle estimate is 8.1 percentage points above the measured one; low and high end bracket the measured number.
By their numbers in this assay, from the lowest: compounds 4, 1, 3 and 2 (each within the scatter of the next, the first and the last beyond it).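

Chloro in place of methyl, on the aromatic carbon para to a large group, gives a number 11 percentage points lower from compound 2 to compound 4 (beyond the scatter) in this assay. This is the first step among these compounds to pass beyond the scatter, so this position does respond to a single exchange, whereas the earlier step, a number 2.5 percentage points higher from compound 1 to compound 3 (within the scatter), involved a different exchange and could not show a clear change. Nothing shown here explains what lies behind the new step.

As far as these compounds go, whether an amine, a carboxylic acid or a longer chain at this position would give a number nearer that of compound 2 or that of compound 4 remains open. This single pair also cannot tell whether the 4-methylphenyl to 4-chlorophenyl change would have the same result on other compounds.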